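Phenyl to methyl on the fused core: compound 4

This account rests on a few compounds, and the source may have more. Where it says the series, first, only, none or still open, it means among the compounds named here.

Measured in an assay on isolated protein for inhibition of ribosomal protein S6 kinase alpha-1 (Homo sapiens), read by mobility shift assay, tested at 30 uM; a lower number here means less inhibition, a higher number more inhibition at the concentration tested (going by the name of the read-out):
compound 1, `Cc1cc2c(c(NC(=O)Nc3ccccc3)nn2C)c(=O)[nH]1`: -11%
compound 2, `Cc1cc2nc(N)nc(N)c2c(=O)[nH]1`: -4%
compound 3, `Cc1cc2nc(-c3ccccc3)nc(N)c2c(=O)[nH]1`: 14%

Compound 3 stands highest of the three numbers in this assay, beyond the scatter from both compound 2 and compound 1. Among the compounds with values here, the only measured single-place change is a number 18 percentage points higher from compound 2 to compound 3 (beyond the scatter), phenyl in place of amino on an aromatic carbon, a modest gain.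

Compound 4, `Cc1nc(N)c2c(=O)[nH]c(C)cc2n1`, differs from compound 3 by methyl in place of phenyl on an aromatic carbon. This removes the phenyl whose entry carried the gain in a number 18 percentage points higher from compound 2 to compound 3 (beyond the scatter), so part of that gain is expected to be lost; methyl is not amino, so a full return to the level of compound 2 is not assumed. Compound 4 is therefore expected near 3% in this assay, within -12% to 17%. The expected step is a number 11 percentage points lower from compound 3 to compound 4 (beyond the scatter), a modest drop.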

Compound 4, a percentage reported as inhibition, at one concentration (the size of the read-out at that concentration, not a potency): -23%
Beside the measured number, compound 4's estimate is 26 percentage points above it; measured number outside the range, below it.
By their numbers in this assay, from the lowest: compound 4; then compounds 1 and 2 (each within the scatter of the next); then compound 3.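

At the aromatic carbon between two ring nitrogen atoms, the outcome in this assay tracks the group present: methyl in place of phenyl gives a number 37 percentage points lower from compound 3 to compound 4 (beyond the scatter), a larger step than any seen before. Methyl also falls short of amino, with a number 19 percentage points lower from compound 2 to compound 4 (beyond the scatter), so across compound 2, compound 3 and compound 4 the three groups separate beyond the scatter, with methyl lowest and phenyl highest. No evidence on hand accounts for this order.

As far as these compounds go, whether a non-aromatic ring such as cyclohexyl or a longer chain such as propyl would hold the level of compound 3 remains open. So does the effect of a substituted phenyl, such as 4-methoxyphenyl, at this carbon.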